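The compounds below may be only part of what the source reports. "The series", "measured", "known", "first", "only" and "open" are said of these compounds alone.

The measured compounds in an ADME assay on cells (Homo sapiens) for cytotoxicity (a lower number here means that less compound is tolerated, a higher number that more compound is tolerated), are these. Compound 1 `CC(C)(CCCOc1ccc(-c2ccc(Cl)cc2)cc1)CN1CCN(c2ccncc2)C1=O` gives 20000 nM. Compound 2 `CC(C)C(CCOc1ccc(-c2ccc(Cl)cc2)cc1)CCN1CCN(c2ccncc2)C1=O` gives only a limit of the assay, > 25000 nM. Compound 3 `CCC(CCOc1ccc(-c2ccc(Cl)cc2)cc1)CCN1CCN(c2ccncc2)C1=O` likewise gives only a limit, > 25000 nM.

Compound 3 differs from compound 2 by hydrogen in place of methyl on a saturated chain carbon bound to two saturated chain carbons. The step that the two limits leave unreadable from compound 2 to compound 3 cannot be read, because of the limit of > 25000 nM in this assay, at which 2 of the 3 values shown sit. The difference between the cores of compound 1 and compound 2 is not broken down here.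

Compound 4 `CC(CCCOc1ccc(-c2ccc(Cl)cc2)cc1)CN1CCN(c2ccncc2)C1=O` differs from compound 1 by hydrogen in place of methyl on a saturated chain carbon bound to three saturated chain carbons. The place differs from the earlier change, a carbon bound to three saturated chain carbons rather than two, so this is the same kind of change, not the same one. The expectation for compound 4 rests only on compound 1, which gives 20000 nM, since the earlier step is unreadable. Compound 4 is therefore expected to give 20000 nM, between 9000 nM and 40000 nM. That expected value means a step of no change at the digits printed from compound 1 to compound 4 (within the scatter) in this assay.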

Compound 4, half-maximal cytotoxic concentration: > 25000 nM
Compound 4 ended at the assay's limit; the forecaster's own chance of this, stated with the estimate: 40%; middle value at least 1.2-fold (0.09 log units) from the limit.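

In this assay, hydrogen in place of methyl on a saturated chain carbon bound to three saturated chain carbons gives an at least 1.2-fold higher number from compound 1 to compound 4 (0.09 log units; that floor lies within the scatter). Compound 4 gives only a limit of the assay, > 25000 nM. Whether this change carries from one core to another cannot be said, because the step from compound 2 to compound 3, the same kind of change at a different place, cannot be read: the limit of > 25000 nM in this assay, at which 3 of the 4 values shown sit.

The compounds shown leave open what an amine, a carboxylic acid or a longer chain on these saturated chain carbons would give in this assay. They also leave open how far compound 2, compound 3 and compound 4 lie from that limit.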